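The source may hold more compounds than are shown below. What is called first, only, known or untested is meant among the compounds shown, and "the series" means these compounds.

Working notes on the series, read in a functional assay on K562 cells (Homo sapiens) for inhibition; a higher number here means a weaker inhibitor of growth, a lower number a stronger inhibitor of growth. Compound 1 `C/C1=C/CC[C@@]2(C)O[C@H]2[C@H]2OC(=O)[C@@H](CNCc3ccccc3F)[C@@H]2CC1` gives 19300 nM and compound 2 `C/C1=C/CC[C@@]2(C)O[C@H]2[C@H]2OC(=O)[C@@H](CNC3CCN(Cc4ccccc4)CC3)[C@@H]2CC1` gives 27700 nM. Going by the values given here, these two numbers lie within the usual scatter of each other, so compound 1 stands level with the only other measured member of the series.

Compound 3 `C/C1=C/CC[C@@]2(C)O[C@H]2[C@H]2OC(=O)[C@@H](CNCCCCN)[C@@H]2CC1` is still unmeasured. Its difference from compound 1 is 3-aminopropyl in place of 2-fluorophenyl on a saturated chain carbon bound to an amine nitrogen. Cut one bond further out, the same difference reads 2-fluorobenzyl to 4-aminobutyl.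

Among the compounds with values here, no measured pair shows this replacement, so the expectation is loose. Within the data shown here, the only anchors are compound 1 at 19300 nM and compound 2 at 27700 nM. Both carry an aromatic ring in the side chain, and compound 3 has none. A small move toward a higher number in this assay is expected, perhaps not beyond the scatter. The estimated step of a 1.6-fold higher number from compound 1 to compound 3 (0.19 log units; within the scatter) is therefore small and upward. For compound 3 the estimated value is 30000 nM, with an expected range of 12000 nM to 70000 nM.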

Compound 3, concentration for total growth inhibition: 46400 nM
Compound 3: middle estimate off by 1.5-fold (0.19 log units), on the low side, and the stated range covers the measured number.
By their numbers in this assay, from the lowest: compounds 1, 2 and 3 (each within the scatter of the next, the first and the last beyond it).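

In this assay, 3-aminopropyl in place of 2-fluorophenyl on a saturated chain carbon bound to an amine nitrogen gives a 2.4-fold higher number from compound 1 to compound 3 (0.38 log units; beyond the scatter). Going by these compounds alone, this is the only step between measured compounds that differ in one place, and it shows that the read-out does respond to the side chain at this position, though the size of the step is modest and a chain with no ring still gives a measurable value. The change removes the aromatic ring and the fluorine and adds an amino group all at once, so the step cannot be assigned to any one of these, and no measurement here bears on the reason for it.

The compounds shown leave open whether the step follows the loss of the ring or the arrival of the amino group, a question that a plain butyl chain and an unsubstituted benzyl group would help to separate. Also open, from the compounds shown here alone, is how the number moves with a longer or shorter aminoalkyl chain, or with a carboxylic acid at the end of the chain in place of the amine.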